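The compounds below may be only part of what the source reports. "The series", "measured", "known", "first", "only" and "open" are said of these compounds alone.

In an assay on membranes from HeLa cells for displacement of a labelled ligand from adenosine receptor A3 (Homo sapiens), read by scintillation counting, with a stated time of 180 min, tested at 1 uM (on this read-out higher numbers stand for more inhibition at the one concentration tested (going by the name of the read-out) and lower numbers for less inhibition), compound 1 `COC(=O)C1=C(C)N(C)C(=O)NC1c1cccs1` gives 15%, compound 2 `CCCOC(=O)C1=C(C)N(C)C(=O)NC1c1cccs1` gives 4%, and compound 3 `CC1=C(C(=O)OCC(C)C)C(c2cccs2)NC(=O)N1C` gives 5%. Compound 3 thus stands second highest of the three, within the scatter of both compound 2 and compound 1. Compound 4 `CC1=C(C(=O)OC(C)(C)C)C(c2cccs2)NC(=O)N1C` differs from compound 3 by tert-butyl in place of isobutyl on an oxygen next to a carbonyl group. Every measured step alters the group on the oxygen next to a carbonyl group: a number 11 percentage points lower from compound 1 to compound 2 (beyond the scatter), a number 10 percentage points lower from compound 1 to compound 3 (within the scatter) and a number 1 percentage points higher from compound 2 to compound 3 (within the scatter). Going by the values given here, the one step that changes only branching of that group, between compound 2 and compound 3, stayed within the scatter. The expected step in this assay is therefore no change at the digits printed from compound 3 to compound 4 (within the scatter), none beyond the scatter. Compound 4 is estimated at 5%, between -5% and 15%.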

Compound 4, a percentage reported as inhibition, at one concentration (the size of the read-out at that concentration, not a potency): 22%
Beside the measured number, compound 4's estimate is 17 percentage points below it, outside the stated range (above it).
By their numbers in this assay, from the lowest: compounds 2, 3, 1 and 4 (each within the scatter of the next, the first and the last beyond it).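

In this assay, the group on the oxygen next to a carbonyl group now shows that a change in its branching alone can exceed the scatter: with the same atoms joined differently, the swap of isobutyl for tert-butyl gives a number 17 percentage points higher from compound 3 to compound 4 (beyond the scatter) in the series. Tert-butyl in place of propyl likewise gives a number 18 percentage points higher from compound 2 to compound 4 (beyond the scatter) here, while tert-butyl in place of methyl gives a number 7 percentage points higher from compound 1 to compound 4 (within the scatter) and so does not separate the two. No evidence at hand accounts for this result.

Open, going by these compounds, is how a benzyl group, a longer chain or a carboxylic acid would read at this place. Also open, on these data alone, is whether tert-butyl would have the same effect on a core carrying another group instead of thiophene.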